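Swapping a halogen on an aryl ring of a triazole series

The source may hold more compounds than are shown below. What is called first, only, known or untested is meant among the compounds shown, and "the series" means these compounds.

Three compounds share one core, and all three have been tested in an assay on cells (strain Sprague-Dawley) for inhibition of Polyunsaturated fatty acid 5-lipoxygenase (Rattus norvegicus), with a stated time of 30 min; a lower number here means a stronger inhibitor, a higher number a weaker inhibitor. Compound 1, `CC(=O)Oc1ccc(/C=C/C(=O)OCCCSc2nc(-c3ccc(S(C)(=O)=O)cc3)n(-c3ccc(Br)cc3)n2)cc1OC(C)=O`, gives 990 nM. Compound 2, `NS(=O)(=O)c1ccc(-c2nc(SCCCOC(=O)/C=C/c3ccc(O)c(O)c3)nn2-c2ccccc2)cc1`, gives 770 nM. Compound 3, `CC(=O)Oc1ccc(/C=C/C(=O)NCCCSc2nc(-c3ccc(S(C)(=O)=O)cc3)n(-c3ccc(Br)cc3)n2)cc1OC(C)=O`, gives 990 nM in this assay, level with compound 1 at the digits shown, and the gap to compound 2 also lies within the usual scatter, so the three numbers cannot be told apart with confidence.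

Compound 4, `CC(=O)Oc1ccc(/C=C/C(=O)NCCCSc2nc(-c3ccc(S(C)(=O)=O)cc3)n(-c3ccc(F)cc3)n2)cc1OC(C)=O`, differs from compound 3 in one place: fluoro in place of bromo on an aromatic carbon. Among the compounds with values here, no pair among the measured compounds shows this exchange, so its effect here is unknown. With nothing in the measured numbers pointing one way, the expectation is a step from compound 3 to compound 4 of about a 1.1-fold higher number from compound 3 to compound 4 (0.05 log units; within the scatter), that is, none beyond the scatter, in either direction. Compound 4 is therefore estimated at 1100 nM in this assay, with a likely range from 400 nM to 3000 nM.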

Compound 4, half-maximal inhibitory concentration: 980 nM
For compound 4 the middle estimate is 1.1-fold (0.05 log units) above the measured one, within the range that was stated.
By their numbers in this assay, from the lowest: compounds 2, 4, 1 and 3 (each within the scatter of the next).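

In this assay, within the data shown here, replacing 4-bromophenyl with 4-fluorophenyl gives a 1.0-fold lower number from compound 3 to compound 4 (0.00 log units; within the scatter), the first direct reading of any change at this position. In this single pair, fluoro and bromo on the aromatic carbon para to a large group cannot be told apart by this measurement, even though the two halogens are different atoms. No measurement shown here accounts for this result.

The compounds shown leave open whether this position tolerates groups other than halogens, such as a methoxy group, an amine or a carboxylic acid, since only fluoro and bromo can be compared here. From the compounds shown here alone, it also remains open whether the same exchange would read the same way in compound 1, where an ester link replaces the amide link of compound 3.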